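Swapping the nitrogen-bound arm of a fused thiophene amide

The compounds below may be only part of what the source reports. "The series", "measured", "known", "first", "only" and "open" are said of these compounds alone.

Measured so far:
compound 1 `NC(=O)c1c(NC(=O)c2ccccc2Cl)sc2c1CCN(Cc1ccc([N+](=O)[O-])cc1)C2` — 11400 nM
compound 2 `NC(=O)c1c(NC(=O)c2ccc(C(F)(F)F)cc2)sc2c1CCN(Cc1ccc(Cl)cc1Cl)C2` — 14900 nM

Both numbers come from a functional assay on HL-60 cells (Homo sapiens) for antiproliferative activity, with a stated time of 24 h; on this read-out higher numbers stand for weaker inhibition and lower numbers for stronger inhibition. Compound 1 shows the lower of the two, but compound 2 lies within the scatter of it, so the two cannot be ranked. Compound 3 `NC(=O)c1c(NC(=O)c2ccccc2Cl)sc2c1CCN(C(=S)Nc1ccccc1I)C2` awaits measurement. It differs from compound 1 in one place: a group of 10 heavy atoms (7 carbon, 1 nitrogen, 1 sulfur, 1 iodine; one six-membered aromatic ring of carbon only) in place of a group of 10 heavy atoms (7 carbon, 1 nitrogen, 2 oxygen; one six-membered aromatic ring of carbon only), on an amine nitrogen in a ring. Among the measured compounds shown here, no measured pair shows the effect of such an exchange, so the step is expected to stay within the scatter, a 1.1-fold lower number from compound 1 to compound 3 (0.06 log units; within the scatter). Compound 3 is estimated at 10000 nM, with a range from 3000 nM to 35000 nM.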

Compound 3, half-maximal inhibitory concentration: 4430 nM
The estimate for compound 3 lay 2.3-fold (0.35 log units) above the measured number, and the stated range covers the measured number.
By their numbers in this assay, from the lowest: compound 3; then compounds 1 and 2 (each within the scatter of the next).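

In this assay the exchange gives a 2.6-fold lower number from compound 1 to compound 3 (0.41 log units; beyond the scatter) when made on the amine nitrogen in the ring. So this position can shift the read-out, which compounds 1 and 2 could not show, since they differ in more than one place. The step is modest, and the entering group differs from 4-nitrobenzyl in several features at once; no measurement at hand explains it. Which feature matters stays open, including whether the sulfur or the iodine is needed. Going by these compounds, the effect of an unsubstituted benzyl group or a carboxylic acid on this nitrogen also remains unknown.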